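The source may hold more compounds than are shown below. What is called first, only, known or untested is meant among the compounds shown, and "the series" means these compounds.

Values in a functional assay on MCF7 cells (Homo sapiens) for cytotoxicity, read by MTT assay, with a stated time of 96 h (on this read-out higher numbers stand for weaker inhibition and lower numbers for stronger inhibition), stand as follows
- compound 1 `COc1cc(C(=O)c2cn(-c3cccc(N)c3)cc2-c2ccccc2Cl)cc(OC)c1OC` gives 40 nM
- compound 2 `COc1cc(C(=O)c2cn(-c3cccc(N)c3)cc2-c2cccc([N+](=O)[O-])c2)cc(OC)c1OC` gives 510 nM
- compound 3 `COc1cc(C(=O)c2cn(-c3cccc(N)c3)cc2-c2ccc([N+](=O)[O-])cc2)cc(OC)c1OC` gives 110 nM

Compound 2 carries the highest number of the three and is the weakest of this set, with its steps to both others beyond the scatter. The next compound is compound 4 `COc1cc(C(=O)c2cn(-c3ccc(C)cc3)cc2-c2cccc([N+](=O)[O-])c2)cc(OC)c1OC` with 4-methylphenyl in place of 3-aminophenyl on an aromatic nitrogen, and the counted difference reads 4-methylphenyl in place of 3-aminophenyl on an aromatic nitrogen for this swap.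

Going by the values given here, three measured steps bear on it only indirectly. The step of a 13-fold higher number from compound 1 to compound 2 (1.11 log units; beyond the scatter) is large, while a 2.8-fold higher number from compound 1 to compound 3 (0.44 log units; beyond the scatter) and a 4.6-fold lower number from compound 2 to compound 3 (0.67 log units; beyond the scatter) are modest. Among the compounds with values here, all three exchange the other aryl group and keep 3-aminophenyl, so no measured compound tests the present change. They show only how far a single aryl swap has moved the number in this series.

In this assay a modest step toward a higher number is expected, and this direction is a tentative lean that the data do not establish. The expected move is a 2.4-fold higher number from compound 2 to compound 4 (0.37 log units; beyond the scatter) as a working figure. For compound 4 the estimate is 1200 nM with an expected range from 250 nM to 6000 nM pending measurement.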

Compound 4, half-maximal inhibitory concentration: 210 nM
Beside the measured number, compound 4's estimate is 5.7-fold (0.76 log units) above it, outside the stated range (below it).
By their numbers in this assay, from the lowest: compound 1; then compounds 3 and 4 (each within the scatter of the next); then compound 2.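

In this assay the group on the aromatic nitrogen is now shown to move the number, which the earlier compounds could not show, as all of them keep 3-aminophenyl there. With the 3-nitrophenyl group held fixed, exchanging 3-aminophenyl for 4-methylphenyl gives a 2.4-fold lower number from compound 2 to compound 4 (0.39 log units; beyond the scatter) and so, for this one pair, the hydrogen-bond donor and acceptor counted on the leaving group are not needed to hold the number at or under that of compound 2. Nothing at hand gives a reason for the direction or size of this step.

The swap changes both the substituent and its place on the ring, so this single pair cannot separate the two changes; 4-aminophenyl or 3-methylphenyl on the same nitrogen would divide them, and an unsubstituted phenyl would give a common reference for both. As far as these compounds go, it also remains open whether the step carries over to the compounds bearing 2-chlorophenyl or 4-nitrophenyl, with only the 3-nitrophenyl pair available so far.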